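Trisubstituted benzhydrazones: swapping the aryl partner

The compounds below may be only part of what the source reports. "The series", "measured", "known", "first", "only" and "open" are said of these compounds alone.

Compound 2 `COc1cc(C(=O)N/N=C/c2ccccc2F)cc(OC)c1OC` holds the highest of the three measured numbers in a functional assay on BGC-823 cells (Homo sapiens) for antiproliferative activity, read by MTT assay, tested at 5 uM; on this read-out lower numbers stand for a weaker effect and higher numbers for a stronger effect at the one concentration tested: compound 2 gives 76.5%. Its nearest neighbour is compound 1 `COc1cc(C(=O)N/N=C/c2ccccc2C(F)(F)F)cc(OC)c1OC`, which in this assay gives 35.6%, and the furthest is compound 3 `COc1ccc(/C=N/NC(=O)c2cc(OC)c(OC)c(OC)c2)c(OC)c1`, which in this assay gives 3.6%.

Compound 4 `COc1cc(C(=O)N/N=C/c2ccc(Cl)c(Cl)c2)cc(OC)c1OC` differs from compound 2 in one place, (3,4-dichlorophenyl in place of 2-fluorophenyl on a carbon with a double bond to nitrogen). Going by the values given here, no measured step changes the whole aryl group in this way, so none bears directly on it. Among the compounds with values here, the one measured step, a number 40.9 percentage points higher from compound 1 to compound 2 (beyond the scatter), shows that exchanging a single substituent on that ring can move the read-out by a large amount. Compound 3, with a different pattern of groups on the same ring, stands far below compound 2. The three compounds together show that the read-out in this assay is sensitive to what sits on this ring, but they do not show in which direction a 3,4-dichlorophenyl would move it.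

The expectation for compound 4 is therefore a step of a number 28.5 percentage points lower from compound 2 to compound 4 (beyond the scatter), a decrease of moderate size with wide uncertainty. Compound 4 is estimated at 48%, between 15% and 78%.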

Compound 4, a percentage reported as inhibition, at one concentration (the size of the read-out at that concentration, not a potency): 32.7%
Beside the measured number, compound 4's estimate is 15.3 percentage points above it; the range from low to high includes it.
By their numbers in this assay, from the lowest: compound 3; then compounds 4 and 1 (each within the scatter of the next); then compound 2.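

In this assay, the change of the whole aryl group gives a first direction for this position: a number 43.8 percentage points lower from compound 2 to compound 4 (beyond the scatter). Read with a number 40.9 percentage points higher from compound 1 to compound 2 (beyond the scatter), this shows that 2-fluorophenyl holds the highest number among the compounds that differ from compound 2 in one place, since both the 3,4-dichlorophenyl of compound 4 and the trifluoromethyl-bearing ring of compound 1 stand far below it, and those two lie within the scatter of each other. No supporting measurement here bears on why 3,4-dichlorophenyl gives the lower number in this place.

Compound 4 removes the fluoro group and brings in two chlorines at once, so the compounds shown cannot say how much of the step belongs to losing the fluoro group and how much to either chlorine. As far as these compounds go, how a phenyl ring with a single chlorine, or one carrying an amine or a carboxylic acid, would compare with the 2-fluorophenyl of compound 2 stays open, as does whether the order seen at this one concentration would hold at others.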